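From isopropoxy to cyclopropylmethoxy in a small series

The source may report more compounds than this note shows. Statements on the series, on what has been measured and on what is new or still open speak of the compounds shown alone.

Of the compounds shown here, three sharing one core have been measured in a functional assay on the whole organism (strain Sprague-Dawley) for inhibition, with Rattus norvegicus as the target, with a stated time of 10 min; on this read-out lower numbers stand for an effect already at smaller amounts and higher numbers for an effect only at larger amounts of compound. Here compound 1 `O=C(O)c1cnc(-c2ccccc2F)[nH]c1=O`, which carries fluoro, gives 5 mg/kg, compound 2 `COc1ccccc1-c1ncc(C(=O)O)c(=O)[nH]1`, which carries methoxy, gives 10 mg/kg, and compound 3 `CC(C)Oc1ccccc1-c1ncc(C(=O)O)c(=O)[nH]1`, which carries isopropoxy, gives 0.8 mg/kg. Compound 3 thus has the lowest of the three numbers, and its gaps to both others lie beyond the scatter.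

Compound 4 `O=C(O)c1cnc(-c2ccccc2OCC2CC2)[nH]c1=O` departs from compound 3 with cyclopropylmethyl in place of isopropyl on an oxygen on an aromatic ring. Going by the values given here, the closest evidence is a 13-fold lower number from compound 2 to compound 3 (1.10 log units; beyond the scatter), the only measured step that changes the group on that oxygen. Two further steps replace fluoro: a 2.0-fold higher number from compound 1 to compound 2 (0.30 log units; within the scatter) and a 6.3-fold lower number from compound 1 to compound 3 (0.80 log units; beyond the scatter). Among the compounds with values here, no measured compound has a ring on that oxygen, so the data give no direct reading of this change. Both groups are uncharged and made of carbon only, so no clear shift is expected in this assay. Still, the large step to compound 3 shows that this oxygen substituent can move the number considerably, so the range is kept wide. The expected step is a 1.3-fold higher number from compound 3 to compound 4 (0.10 log units; within the scatter), which amounts to no expected change beyond the scatter. For compound 4 the estimated value is 1 mg/kg, with an expected range from 0.3 mg/kg to 4 mg/kg.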

Compound 4, dose for 50% inhibition: 0.1 mg/kg
Beside the measured number, compound 4's estimate is 10-fold (1.00 log units) above it; measured number below the stated range.
By their numbers in this assay, from the lowest: compound 4; then compound 3; then compounds 1 and 2 (each within the scatter of the next).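

In this assay, the oxygen on an aromatic ring proves sensitive not only to the move away from methyl but also to an exchange between two uncharged, carbon-only groups, with an 8.0-fold lower number from compound 3 to compound 4 (0.90 log units; beyond the scatter) for isopropyl giving way to cyclopropylmethyl. Compound 3 therefore does not mark the end of the range at this position: changing the group on that oxygen spans a 100-fold lower number from compound 2 to compound 4 (2.00 log units; beyond the scatter) in all, and replacing fluoro on the aromatic carbon with cyclopropylmethoxy gives a 50-fold lower number from compound 1 to compound 4 (1.70 log units; beyond the scatter) as well. This is also the first ring on that oxygen in the series, but a single compound cannot separate the contribution of the three-membered ring from that of the larger carbon count. Nothing in the data available here explains the size of this step.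

The compounds shown leave open whether a straight butyl chain or a cyclobutylmethyl group on that oxygen would give a number like that of compound 4, and so whether the ring itself matters. They also leave open what the carboxylic acid contributes, since all four compounds carry it.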